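Changing the Aromatic Group on a Shared Core

The source may hold more compounds than are shown below. What is called first, only, known or untested is meant among the compounds shown, and "the series" means these compounds.

In a functional assay on HeLa cells (Homo sapiens) for cytotoxicity, read by MTT assay, with a stated time of 48 h (on this read-out lower numbers stand for stronger inhibition and higher numbers for weaker inhibition), compound 1 `CC1(C)CCC[C@]2(C)[C@@H](CC[C@@](C)(O)/C=C/c3ccc(Cl)nc3)[C@](C)(O)CC[C@@H]12` gives 3680 nM. Compound 2 `COc1cccc(/C=C/[C@](C)(O)CC[C@@H]2[C@@]3(C)CCCC(C)(C)[C@@H]3CC[C@@]2(C)O)c1OC` gives 3880 nM, which places it level with compound 1 once the usual scatter of repeated measurements is considered. Compound 3 `Cc1cccc(C)c1/C=C/[C@](C)(O)CC[C@@H]1[C@@]2(C)CCCC(C)(C)[C@@H]2CC[C@@]1(C)O` keeps the shared core and alters only the aromatic group of compound 2: 2,6-dimethylphenyl in place of 2,3-dimethoxyphenyl on a double-bonded chain carbon bound to a double-bonded chain carbon. This puts 2,6-dimethylphenyl in place of 2,3-dimethoxyphenyl on a double-bonded chain carbon bound to a double-bonded chain carbon.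

For the measured compounds named here, only one measured step bears on this change: a 1.1-fold higher number from compound 1 to compound 2 (0.02 log units; within the scatter), with 2,3-dimethoxyphenyl in place of 6-chloropyridin-3-yl. That exchange at the same place stayed within the scatter, though a single step is thin evidence. The expected result in this assay is therefore a 1.1-fold lower number from compound 2 to compound 3 (0.04 log units; within the scatter), a step no larger than the scatter. Compound 3 is estimated at 3500 nM, with an expected range of 1800 nM to 7000 nM.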

Compound 3, half-maximal inhibitory concentration: 3460 nM
Compound 3: middle estimate off by 1.0-fold (0.00 log units), on the high side; the range from low to high includes it.
By their numbers in this assay, from the lowest: compounds 3, 1 and 2 (each within the scatter of the next).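

Exchanging the aromatic group for one without oxygen atoms leaves the reading in this assay within the scatter, with a 1.1-fold lower number from compound 2 to compound 3 (0.05 log units; within the scatter) and a 1.1-fold lower number from compound 1 to compound 3 (0.03 log units; within the scatter). The oxygen atoms of 2,3-dimethoxyphenyl and the ring nitrogen and chlorine of 6-chloropyridin-3-yl are therefore not required for a number at this level, since the all-carbon 2,6-dimethylphenyl reads alike among these three compounds. No measurement here accounts for this lack of separation.

The compounds shown leave open whether this insensitivity reaches beyond these three aromatic groups, for instance to a phenyl ring carrying an amine or a carboxylic acid. They also leave open whether a saturated chain in place of the aromatic ring, on the same double-bonded chain carbon, would read differently.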